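Hydroxycycloalkyl amine variation on the shared core

This account rests on a few compounds, and the source may have more. Where it says the series, first, only, none or still open, it means among the compounds named here.

Compound 1 `N#Cc1cnc(NCc2cnccc2C(F)(F)F)cc1NC[C@H]1C[C@H](O)C1`: > 10000 nM in an assay on isolated protein for inhibition of protein kinase C delta type (Homo sapiens), read by TR-FRET, with a stated time of 2 h (on this read-out higher numbers stand for weaker inhibition and lower numbers for stronger inhibition), a limit of the assay.
Compound 2 `N#Cc1cnc(NCc2cnccc2C(F)(F)F)cc1N[C@H]1CC[C@@H](O)CC1`: 4500 nM in this assay.
Compound 3 `N#Cc1cnc(NCc2ccccc2C(F)(F)F)cc1N[C@H]1CC[C@H](O)CC1`: > 10000 nM in this assay, a limit of the assay.

Among the compounds with values here, compound 2 carries the only number in this set. The value of compound 1 is a limit. The value of compound 3 is likewise a limit, so that (the limit of > 10000 nM in this assay, at which 2 of the 3 values shown sit). Compound 4 `N#Cc1cnc(NCc2cnccc2C(F)(F)F)cc1NC[C@H]1CC[C@H](O)CC1` differs from compound 2 by (4-hydroxycyclohexyl)methyl in place of 4-hydroxycyclohexyl on a nitrogen on an aromatic ring. Within the data shown here, the one measured step that bears on this change, an at least 2.2-fold lower number from compound 1 to compound 2 (0.34 log units; beyond the scatter), runs the other way: there the methylene link was removed and the ring enlarged at the same time, and the number fell. Restoring a methylene link while keeping the six-membered ring is expected to push the number back up, with a fair chance that only a limit results. Compound 4 is estimated at 9000 nM (range 3000 nM to 30000 nM). That estimate corresponds to an expected 2.0-fold higher number from compound 2 to compound 4 (0.30 log units; within the scatter).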

Compound 4, half-maximal inhibitory concentration: 2000 nM
For compound 4 the middle estimate is 4.5-fold (0.65 log units) above the measured one, outside the stated range (below it).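

Adding a methylene link to the 4-hydroxycyclohexyl group gives a 2.3-fold lower number from compound 2 to compound 4 (0.35 log units; beyond the scatter), so in this assay the link itself carries no penalty on the six-membered ring. With the link kept, 4-hydroxycyclohexyl in place of 3-hydroxycyclobutyl gives an at least 5.0-fold lower number from compound 1 to compound 4 (0.69 log units; beyond the scatter), which reads the ring change apart from the link change. The value of compound 1 is a limit of the assay, so this step sets only a minimum size: the limit of > 10000 nM in this assay, at which 2 of the 4 values shown sit.

Still open, from the compounds shown here alone, is whether a longer chain, such as an ethylene link to the same ring, lowers the number further. Also open, going by these compounds, is whether an amine in place of the hydroxyl keeps the gain.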